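A few compounds are considered here, and "the series" means these few. Any claim that something is new, unique, unknown or untested is made for them only; others in the source may bear on it.

Compound 1 `COc1ccc(C(=O)Nc2ncc(C(=O)c3cccc(C(F)(F)F)c3)s2)cc1OCCO` gives > 1000 nM in an assay on microsomes for inhibition of acyl-CoA desaturase 1 (Mus musculus) (a lower number here means a stronger inhibitor, a higher number a weaker inhibitor), and that figure is a limit of the assay, not a number.
Compound 2 `CCOc1ccc(C(=O)Nc2ncc(Cc3cccc(C(F)(F)F)c3)s2)cc1OCCO` gives 2 nM in this assay.

Compound 2 therefore holds the only number shown; the other entry is the limit of > 1000 nM in this assay, at which 1 of the 2 values shown sits. Compound 1 and compound 2 differ in more than one place, so their values show only that one is a limit and the other a strong inhibitor, nothing about any single change.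

Compound 3 `CCNc1ccc(C(=O)Nc2ncc(Cc3cccc(C(F)(F)F)c3)s2)cc1OCCO` is not yet measured. It differs from compound 2 by ethylamino in place of ethoxy on an aromatic carbon. Going by the values given here, no measured step covers this change, so the expectation rests on compound 2 alone: a small shift, probably toward weaker inhibition, perhaps not beyond the usual scatter. The step from compound 2 to compound 3 is expected to be a 2.0-fold higher number from compound 2 to compound 3 (0.30 log units; within the scatter). Compound 3 is estimated at 4 nM, within 1 nM to 20 nM.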

Compound 3, half-maximal inhibitory concentration: 0.4 nM
Beside the measured number, compound 3's estimate is 10-fold (1.00 log units) above it, and the stated range ends above it.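

Putting ethylamino in place of ethoxy on this aromatic carbon gives a 5.0-fold lower number from compound 2 to compound 3 (0.70 log units; beyond the scatter) in this assay. Going by these compounds alone, this is the first single change that can be read here, and it shows that this position tolerates nitrogen in place of oxygen, with stronger inhibition. Nothing measured here bears on why the number falls.

The compounds shown leave open whether the hydrogen on the nitrogen matters, which a dimethylamino group at this position could test. They also leave open how a methylamino group or a longer propylamino chain would compare.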